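The source may report more compounds than this note shows. Statements on the series, on what has been measured and on what is new or still open speak of the compounds shown alone.

Within the data shown here, compound 2 `O=C1COc2ccc(-c3nn(-c4ccc(Cl)cc4)cc3-c3ccccc3)cc2N1` gives 52.4% in a functional assay on A549 cells (Homo sapiens) for cytotoxicity, read by colorimetric assay and MTT assay, with a stated time of 3 days, tested at 20 uM (on this read-out lower numbers stand for a stronger effect and higher numbers for a weaker effect at the one concentration tested), the lowest of the two numbers so far; compound 1 `Cc1ccccc1-n1cc(-c2ccccc2)c(-c2ccc3c(c2)NC(=O)CO3)n1` gives 85.3% in this assay, and the step of a number 32.9 percentage points lower from compound 1 to compound 2 (beyond the scatter) is the only one measured. Compound 3 `O=C1COc2ccc(-c3nn(-c4ccccc4)cc3-c3ccccc3)cc2N1` differs from compound 2 by hydrogen in place of chloro on an aromatic carbon, a 4-chlorophenyl to phenyl change. Among the measured compounds shown here, no measured step removes a chloro alone; the single step from compound 1 to compound 2 swaps the whole aryl group, so it bears only loosely on this change. An intermediate value is therefore expected, with the step of a number 15.6 percentage points higher from compound 2 to compound 3 (beyond the scatter) estimated in this assay. Compound 3 is expected to give about 68%, within 45% to 90%.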

Compound 3, a percentage reported as activity, at one concentration (the size of the read-out at that concentration, not a potency): 59.7%
For compound 3 the middle estimate is 8.3 percentage points above the measured one; the measured number falls inside the stated range.
By their numbers in this assay, from the lowest: compounds 2 and 3 (each within the scatter of the next); then compound 1.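

Hydrogen in place of chloro gives a number 7.3 percentage points higher from compound 2 to compound 3 (within the scatter) in this assay, so on this carbon, para to a large group, the chloro is not needed to reach the number seen for compound 2. Hydrogen in place of methyl gives a number 25.6 percentage points lower from compound 1 to compound 3 (beyond the scatter), a step the earlier swap of the whole aryl group could not isolate. No available evidence accounts for either step. From the compounds shown here alone, how an amine or a carboxylic acid on this carbon would read in this assay remains open.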